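A few compounds are considered here, and "the series" means these few. Any claim that something is new, unique, unknown or untested is made for them only; others in the source may bear on it.

Measured in a functional assay on A549 cells (Homo sapiens) for inhibition; on this read-out higher numbers stand for weaker inhibition and lower numbers for stronger inhibition:
- Compound 1 `O=C(CC(CC(=O)NC1Cc2ccccc2C1)c1ccc(Cl)cc1)NCCN1CCCC1` gives 50900 nM
- Compound 2 `CCN(C(=O)CC(CC(=O)NCCN1CCCC1)c1ccc(Cl)cc1)C1Cc2ccccc2C1` gives 22600 nM
- Compound 3 `CN(C(=O)CC(CC(=O)NCCN1CCCC1)c1ccccc1)C1Cc2ccccc2C1` gives > 100000 nM

Compound 3 sits at the limit of > 100000 nM in this assay, at which 1 of the 3 values shown sits, and this is a limit of the assay, not a number. Compound 4 `CN(C(=O)CC(CC(=O)NCCN1CCCC1)c1ccc(Cl)cc1)C1Cc2ccccc2C1` differs from compound 3 by a single change (chloro in place of hydrogen on an aromatic carbon), which is chloro in place of hydrogen on an aromatic carbon, or phenyl to 4-chlorophenyl.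

Among the compounds with values here, no measured step tests this change directly. The closest evidence comes from the two compounds that already carry the 4-chlorophenyl group. Compound 1 has hydrogen on the amide-type nitrogen and compound 2 has ethyl there, and the modest 2.3-fold lower number from compound 1 to compound 2 (0.35 log units; beyond the scatter) separates them. Compound 4 has methyl on that nitrogen, so it should land near compound 1 at 50900 nM and compound 2 at 22600 nM. A lower number than for compound 3, meaning stronger inhibition, is therefore expected, with an estimated at least 2.8-fold lower number from compound 3 to compound 4 (0.45 log units; beyond the scatter). For compound 4 the expected value is 35000 nM, within an estimated range of 15000 nM to 85000 nM.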

Compound 4, half-maximal inhibitory concentration: 56000 nM
For compound 4 the middle estimate is 1.6-fold (0.20 log units) below the measured one; the range from low to high includes it.
By their numbers in this assay, from the lowest: compound 2; then compounds 1 and 4 (each within the scatter of the next). At a limit, above all of these: compound 3.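

In this assay, going by these compounds, chloro in place of hydrogen on this aromatic carbon gives an at least 1.7-fold lower number from compound 3 to compound 4 (0.25 log units; that floor lies within the scatter), so the change yields a measured number, although the true size of the gain stays unknown. The value of compound 3 is only a limit of the assay, not a number: the limit of > 100000 nM in this assay, at which 1 of the 4 values shown sits. With 4-chlorophenyl in place, methyl on the amide-type nitrogen gives a 1.1-fold higher number from compound 1 to compound 4 (0.04 log units; within the scatter), while the comparison with ethyl on that nitrogen gives a 2.5-fold higher number from compound 2 to compound 4 (0.39 log units; beyond the scatter), so only the ethyl group separates from the others here.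

On these data alone, whether fluoro or methoxy in place of the chloro would give a similar number remains open. So does the outcome with a longer chain, such as propyl, on the amide-type nitrogen.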